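The source may report more compounds than this note shows. Statements on the series, on what has been measured and on what is new or still open speak of the compounds shown alone.

In an ADME assay (liver) for metabolic stability, with Liver microsome (Rattus norvegicus) as the target, using microsomes and NADPH, with a stated time of 30 min, tested at 1 uM (a lower number here means slower removal, a higher number faster removal of the compound), compound 3 (`CCn1cc(-c2cc(C(O)(C(F)(F)F)C(F)(F)F)cnc2N2CCN(S(=O)(=O)c3ccc(N)nc3)CC2)cn1`) gives 194 mL.min-1.g-1, the highest of the three numbers, while compound 1 (`Nc1ccc(S(=O)(=O)N2CCN(c3ncc(C(O)(C(F)(F)F)C(F)(F)F)cc3Br)CC2)cn1`) gives 32 mL.min-1.g-1 and compound 2 (`Nc1ccc(S(=O)(=O)N2CCN(c3ncc(C(O)(C(F)(F)F)C(F)(F)F)cc3C#CCO)CC2)cn1`) gives 65 mL.min-1.g-1. Compound 4 (`CC(C)(C)n1cc(-c2cc(C(O)(C(F)(F)F)C(F)(F)F)cnc2N2CCN(S(=O)(=O)c3ccc(N)nc3)CC2)cn1`) differs from compound 3 in one place: tert-butyl in place of ethyl on an aromatic nitrogen, with tert-butyl in place of ethyl on an aromatic nitrogen. Among the measured compounds shown here, no measured step alters this group alone, so the evidence is indirect. The closest guides are a 6.1-fold higher number from compound 1 to compound 3 (0.78 log units; beyond the scatter) and a 3.0-fold higher number from compound 2 to compound 3 (0.47 log units; beyond the scatter), both modest steps that replace the whole 1-ethyl-1H-pyrazol-4-yl group, a larger change than this one. A smaller step upward is therefore expected, and the estimated step is a 1.3-fold higher number from compound 3 to compound 4 (0.11 log units; within the scatter). Compound 4 is expected at 250 mL.min-1.g-1, with an estimated range of 110 mL.min-1.g-1 to 500 mL.min-1.g-1.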

Compound 4, intrinsic clearance in microsomes: 459 mL.min-1.g-1
Compound 4: the middle estimate sits 1.8-fold (0.26 log units) below what was measured; measured number inside the range.
By their numbers in this assay, from the lowest: compound 1; then compound 2; then compound 3; then compound 4.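

In this assay, tert-butyl in place of ethyl on an aromatic nitrogen gives a 2.4-fold higher number from compound 3 to compound 4 (0.37 log units; beyond the scatter), showing that this substituent alone moves the number beyond the scatter, which swaps of the whole 1-ethyl-1H-pyrazol-4-yl group could not show. Among the compounds shown here, the 1-(tert-butyl)-1H-pyrazol-4-yl group also gives a 7.1-fold higher number from compound 2 to compound 4 (0.85 log units; beyond the scatter) and a 14-fold higher number from compound 1 to compound 4 (1.16 log units; beyond the scatter), the second being the only large step here. Nothing shown bears on the reason for this rise.

On these data alone, how a methyl group, a cyclopropyl ring or a 2-hydroxyethyl chain on this nitrogen would read in this assay stays open.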